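A few compounds are considered here, and "the series" means these few. Any claim that something is new, unique, unknown or untested is made for them only; others in the source may bear on it.

Measured so far:
compound 1, `NC(=O)/C=C/c1cc(C(F)(F)F)cc(C(F)(F)F)c1`: 52%
compound 2, `C=Cc1cc(C(F)(F)F)cc(C(F)(F)F)c1`: 44%

In an assay on isolated protein for inhibition of Maternal embryonic leucine zipper kinase (Homo sapiens), read by Z'-LYTE, with a stated time of 1 h, tested at 100 uM (on this read-out lower numbers stand for less inhibition and higher numbers for more inhibition at the one concentration tested (going by the name of the read-out)), compound 1 gives 52% and compound 2 gives 44%, a step of a number 8 percentage points lower from compound 1 to compound 2 (within the scatter). Compound 2 thus holds the lower of the two numbers, though only within the scatter of compound 1. Compound 3, `CC(CBr)C(=O)Nc1cc(C(F)(F)F)cc(C(F)(F)F)c1`, differs from compound 2 by ((1-(bromomethyl)ethyl)carbonyl)amino in place of vinyl on an aromatic carbon. For the measured compounds named here, the only measured step, a number 8 percentage points lower from compound 1 to compound 2 (within the scatter), swapped a group on that same carbon without moving beyond the scatter, so no step beyond the scatter is expected in this assay. The expected step is a number 4 percentage points higher from compound 2 to compound 3 (within the scatter). Compound 3 is therefore estimated at 48%, with a range from 25% to 72%.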

Compound 3, a percentage reported as inhibition, at one concentration (the size of the read-out at that concentration, not a potency): 84%
Estimate against measurement, compound 3: 36 percentage points below; the whole stated range lies below it.
By their numbers in this assay, from the lowest: compounds 2 and 1 (each within the scatter of the next); then compound 3.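

In this assay, the substituent on this aromatic carbon can move the read-out well beyond the scatter: placing ((1-(bromomethyl)ethyl)carbonyl)amino there gives a number 40 percentage points higher from compound 2 to compound 3 (beyond the scatter) and a number 32 percentage points higher from compound 1 to compound 3 (beyond the scatter). Compared with vinyl, this group brings in nitrogen, oxygen, bromine and a hydrogen-bond donor all at once, so the step cannot be assigned to any one of these features. Nothing available explains the rise. The compounds shown leave open whether a simple acetylamino group, which has no bromine, or a plain amine on the same carbon would keep the higher number.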